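Replacing a Small Amide Group with a Phenylpiperidine

A few compounds are considered here, and "the series" means these few. Any claim that something is new, unique, unknown or untested is made for them only; others in the source may bear on it.

Measured so far:
- compound 1, `COc1ccc(/C=C/c2cc(OC)cc(OC)c2/C=C/C(=O)NC2CC2)cc1`: 10200 nM
- compound 2, `COc1ccc(/C=C/c2cc(OC)cc(OC)c2/C=C/C(=O)N2CCCCC2C)cc1`: 7660 nM
- compound 3, `COc1ccc(/C=C/c2cc(OC)cc(OC)c2/C=C/C(=O)N2CCCCC2)cc1`: 9750 nM

All three compounds were tested in a functional assay on B16-F10 cells (Mus musculus) for inhibition, read by MTT assay, with a stated time of 48 h; a higher number here means a weaker inhibitor, a lower number a stronger inhibitor. Compound 1 gives the highest of the three numbers, yet the gaps to the others are small: a 1.3-fold lower number from compound 1 to compound 2 (0.12 log units; within the scatter) and a 1.0-fold lower number from compound 1 to compound 3 (0.02 log units; within the scatter) both lie within the scatter, as does a 1.3-fold higher number from compound 2 to compound 3 (0.10 log units; within the scatter). So far, changing the group on the carbonyl carbon has not moved the read-out in any clear way.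

Compound 4, `COc1ccc(/C=C/c2cc(OC)cc(OC)c2/C=C/C(=O)N2CCC(c3ccccc3)CC2)cc1`, has not yet been measured. It differs from compound 1 in one place: 4-phenylpiperidin-1-yl in place of cyclopropylamino on a carbonyl carbon

Among the measured compounds shown here, the steps that bear on this are the two in which the cyclopropylamino of compound 1 was exchanged for a saturated six-membered ring with one hetero atom, and neither moved beyond the scatter. Compound 4 is therefore expected to show a step of a 1.2-fold lower number from compound 1 to compound 4 (0.08 log units; within the scatter), that is, no change beyond the scatter. The estimate for compound 4 is 8500 nM, within a range from 4000 nM to 18000 nM.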

Compound 4, half-maximal inhibitory concentration: 9180 nM
Compound 4: middle estimate off by 1.1-fold (0.03 log units), on the low side; low and high end bracket the measured number.
By their numbers in this assay, from the lowest: compounds 2, 4, 3 and 1 (each within the scatter of the next).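

In this assay, the position on the carbonyl carbon now takes 4-phenylpiperidin-1-yl, with 12 heavy atoms and an added aromatic ring, in place of cyclopropylamino, with 4 heavy atoms, and the step is still only a 1.1-fold lower number from compound 1 to compound 4 (0.05 log units; within the scatter). Adding phenyl to the saturated ring gives a 1.1-fold lower number from compound 3 to compound 4 (0.03 log units; within the scatter), and exchanging 2-methylpiperidin-1-yl for the new group gives a 1.2-fold higher number from compound 2 to compound 4 (0.08 log units; within the scatter), so even this much bigger change leaves the read-out flat across all four compounds. No measurement at hand accounts for this flat result.

The compounds shown leave open whether an amine or a carboxylic acid on the added phenyl, or a longer chain on the carbonyl carbon, would move the number beyond the scatter. Also open, on these data alone, is whether changes to the shared core would do so.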